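Nitro group added to the fused ring of compound 1

The source may hold more compounds than are shown below. What is called first, only, known or untested is meant among the compounds shown, and "the series" means these compounds.

Measured so far:
compound 1 `NS(=O)(=O)c1nnc(NCc2nc3ccccc3[nH]2)s1`: 228000 nM
compound 2 `O=[N+]([O-])c1ccc2[nH]c(CNc3c([N+](=O)[O-])ccc4ncccc34)nc2c1`: 274000 nM

In a functional assay on MCF7 cells (Homo sapiens) for cytotoxicity, read by MTT assay (on this read-out lower numbers stand for stronger inhibition and higher numbers for weaker inhibition), compound 1 gives 228000 nM, the lowest of the two numbers in hand. In this assay compound 2 gives 274000 nM; the gap between compound 1 and compound 2 lies within the scatter, so no order between them can be stated, and both sit in a weak range.

Compound 3 `NS(=O)(=O)c1nnc(NCc2nc3cc([N+](=O)[O-])ccc3[nH]2)s1` is the next member. It differs from compound 1 by nitro in place of hydrogen on an aromatic carbon. For the measured compounds named here, no step between two measured compounds is available that isolates this change, and compound 2, though it carries nitro groups on a different core, shares too little with compound 1 to serve as a reference. With nothing to point in either direction, the expected step from compound 1 to compound 3 in this assay is a 1.1-fold lower number from compound 1 to compound 3 (0.06 log units; within the scatter), that is, none beyond the scatter. For compound 3 the estimate in this assay is 200000 nM, with a range from 70000 nM to 600000 nM.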

Compound 3, half-maximal inhibitory concentration: 230000 nM
Compound 3: middle estimate off by 1.2-fold (0.06 log units), on the low side, and the stated range covers the measured number.
By their numbers in this assay, from the lowest: compounds 1, 3 and 2 (each within the scatter of the next).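

In this assay, nitro in place of hydrogen on an aromatic carbon of the six-membered aromatic ring of carbon only, part of a fused or bridged system of two rings, gives a 1.0-fold higher number from compound 1 to compound 3 (0.00 log units; within the scatter). For the compounds shown here, this is the first step that isolates a single change, and it shows that, at this position, adding the nitro group's heavy atoms to the core of compound 1 leaves compound 3 unseparated from compound 1, with both still in the weak range. Nothing measured here bears on the reason for this result.

A single step at a single position does not show whether an amine or a carboxylic acid on the same aromatic carbon would also stay within the scatter of compound 1, or whether either would read clearly apart from it. It also leaves open whether nitro on another carbon of that ring would behave as it does here, so no general statement about nitro on this core can be made from compound 3 alone.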